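A few compounds are considered here, and "the series" means these few. Any claim that something is new, unique, unknown or untested is made for them only; others in the source may bear on it.

Of the compounds shown here, three have been measured in an assay on HEK293 cells for antagonist activity at transient receptor potential cation channel subfamily V member 3 (Homo sapiens), read by FLIPR and calcium flux; on this read-out higher numbers stand for weaker inhibition and lower numbers for stronger inhibition. Compound 1, with the structure `C[C@]1(c2ccc(OC(F)(F)F)cc2)C[C@@](O)(c2ccccn2)CO1`, gives 2460 nM. Compound 2, with the structure `C[C@]1(O)C[C@](c2cccc(C(F)(F)F)c2)([C@H](O)c2ccccn2)C1`, gives 1550 nM. Compound 3, with the structure `C[C@@]1(c2ccc(OC(F)(F)F)cc2)C[C@@](O)(c2ccccn2)CO1`, gives 1120 nM, the lowest of the three numbers, though its gap to compound 2 lies within the scatter and only its gap to compound 1 lies beyond it.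

Compound 4, with the structure `C[C@@]1(c2ccc(OC(F)(F)F)cc2)C[C@](O)(c2ccccn2)CO1`, has not yet been measured. It differs from compound 3 in this way: the two compounds have the same atoms and bonds and differ only in configuration as drawn: 1 of 2 stereo elements differ; a stereocentre at a saturated ring carbon is drawn R in compound 3 and S in compound 4. No group leaves and none enters; the change is purely one of configuration at one ring carbon.

One measured step is of the same kind. Going a 2.2-fold lower number from compound 1 to compound 3 (0.34 log units; beyond the scatter), and because the fact that compounds 1 and 3 differ only in the configuration as drawn that shift can be laid only at the door of configuration. That step concerns the other of the two stereocentres, so it shows that flipping a centre in this core can move the number by a modest amount but does not say in which direction the present flip will move it.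

Compound 4 is therefore expected to sit near compound 3, with a modest shift in either direction possible, and the estimate is 2500 nM, within a range of 900 nM to 7000 nM, amounting to an expected step of a 2.2-fold higher number from compound 3 to compound 4 (0.35 log units; beyond the scatter).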

Compound 4, antagonist equilibrium constant: 1710 nM
Beside the measured number, compound 4's estimate is 1.5-fold (0.16 log units) above it; low and high end bracket the measured number.
By their numbers in this assay, from the lowest: compounds 3, 2, 4 and 1 (each within the scatter of the next, the first and the last beyond it).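

In this assay, inverting the second saturated ring carbon gives a 1.5-fold higher number from compound 3 to compound 4 (0.18 log units; within the scatter), so this centre shows no change beyond the scatter, whereas the earlier inversion of the other centre gave a 2.2-fold lower number from compound 1 to compound 3 (0.34 log units; beyond the scatter). The mirror-image pair adds a new kind of comparison: inverting both centres gives a 1.4-fold lower number from compound 1 to compound 4 (0.16 log units; within the scatter), so these two compounds cannot be told apart in this read-out, and any gap between them could come only from configuration: the fact that compounds 1 and 4 differ only in the configuration as drawn. Taken together, the three stereoisomers of this core show that its configuration matters only modestly here, with only compounds 1 and 3 lying beyond the scatter of each other.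

The compounds shown leave open how the fourth arrangement of the two stereocentres would read, and whether the gap between compounds 1 and 3 would hold up on repeated measurement, since it lies close to the usual scatter. They also leave open whether the second centre would stay as undemanding with an amine in place of the hydroxyl group, or with a nitrile in place of the trifluoromethoxy group.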